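Swapping One Halogen on the Ring of Compound 3

A few compounds are considered here, and "the series" means these few. Any claim that something is new, unique, unknown or untested is made for them only; others in the source may bear on it.

Of the compounds shown here, three have been measured in a functional assay on the whole organism (strain Wistar) for inhibition, with Rattus norvegicus as the target, with stated times of 30 min and 2 h, at a dose of 20 mg/kg by the oral route; a lower number here means less inhibition, a higher number more inhibition at the dose given (going by the name of the read-out). Compound 1, `O=C1OC(c2ccc(Cl)cc2)=C/C1=C\c1ccc(Cl)cc1`, gives 40%. Compound 2, `COc1ccc(/C=C2\C=C(c3ccc(Cl)cc3)OC2=O)cc1OC`, gives 9.33%. Compound 3, `O=C1/C(=C/c2ccc(Cl)cc2)C=C(c2ccc(Cl)cc2)N1Cc1ccccc1`, gives 58.7%, the highest of the three numbers: its gap to compound 1 and its larger gap to compound 2 both lie beyond the scatter of this kind of measurement.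

Compound 4, `O=C1/C(=C/c2ccc(F)cc2)C=C(c2ccc(Cl)cc2)N1Cc1ccccc1`, has not yet been measured. It differs from compound 3 in one place: fluoro in place of chloro on an aromatic carbon. One chlorine leaves and one fluorine enters, on an aromatic carbon of a six-membered aromatic ring of carbon only, para to a large group; no ring, no hydrogen-bond donor or acceptor and no charge is added or lost.

No measured pair among these compounds shows this exchange, so nothing here tells how large its effect is. The step of a number 8.7 percentage points lower from compound 3 to compound 4 (within the scatter) is therefore expected to be small, a slight drop or none beyond the scatter. Compound 4 is estimated at 50%, in a range from 30% to 70%.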

Compound 4, a percentage reported as inhibition, in the whole organism at one dose (the size of the read-out at that dose, not a potency): 58.7%
For compound 4 the middle estimate is 8.7 percentage points below the measured one; the range from low to high includes it.
By their numbers in this assay, from the lowest: compound 2; then compound 1; then compounds 3 and 4 (each within the scatter of the next).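

In this assay, putting fluoro in place of chloro on this ring gives no change at the digits printed from compound 3 to compound 4 (within the scatter). For the compounds shown here, compounds 1 to 3 offered no pair differing in one place, so this is the first direct reading of a single exchange, and it shows that chloro at this position can give way to fluoro without a shift that stands out from the scatter. Nothing on hand explains this result, and no separate measurement of any property of the two compounds accompanies it.

The compounds shown do not tell whether this position would accept a larger or very different group, such as a nitrile, an amine or a carboxylic acid. They also leave open what the same exchange would do on the 4-chlorophenyl ring that both compounds keep.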